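From benzyloxy to propoxy on a shared core

This account rests on a few compounds, and the source may have more. Where it says the series, first, only, none or still open, it means among the compounds named here.

In a functional assay on HCT-8 cells (Homo sapiens) for cytotoxicity (a lower number here means that less compound is needed, a higher number that more compound is needed for the effect), compound 1 `c1ccc(COc2cc(-c3ccccc3)nc3ccccc23)cc1` stands at > 10 ug/mL, which is a limit of the assay and not a number. Within the data shown here, compound 2 `Oc1ccc2nc(-c3ccccc3)cc(O)c2c1`, the only other compound measured, gives 7.75 ug/mL. Compound 3 `CCCOc1cc(-c2ccccc2)nc2ccccc12` differs from compound 1 by one change, benzyloxy to propoxy: ethyl in place of phenyl on a saturated chain carbon bound to an oxygen on an aromatic ring, with ethyl in place of phenyl on a saturated chain carbon bound to an oxygen on an aromatic ring. In this assay, only a small step is expected, a step that the limit leaves unreadable from compound 1 to compound 3, perhaps none beyond the scatter. The estimate for compound 3 is 12 ug/mL, with an expected range of 5 ug/mL to 30 ug/mL.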

Compound 3, half-maximal effective concentration: > 10 ug/mL
Compound 3 gave a limit, no number; the forecaster's own chance of this, stated with the estimate: 60%; the middle value does not contradict the limit.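

No step can be read from compound 1 to compound 3, since both stop at the same limit and neither gives a number: the limit of > 10 ug/mL in this assay, at which 2 of the 3 values shown sit. In this assay the compounds shown leave open whether benzyloxy and propoxy differ at all on the shared core.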